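The compounds below may be only part of what the source reports. "The series", "measured", "known", "first", "only" and "open" are said of these compounds alone.

Working notes on the series in an assay on isolated protein for inhibition of RAC-alpha serine/threonine-protein kinase (Homo sapiens), tested at 30 uM; a lower number here means less inhibition, a higher number more inhibition at the concentration tested (going by the name of the read-out).

Compound 1 `Cn1cnc2c(Sc3ccccc3)ncnc21` gives 0% in this assay. Compound 2 `Cn1cnc2c(Sc3ccc(F)cc3)ncnc21` gives 0%, and compound 3 `CSc1ccc(-c2nc3c(Sc4ccc(F)cc4)ncnc3n2C)cc1` gives 0%. Compound 2 therefore stands level with compounds 1 and 3; the step of no change at the digits printed from compound 1 to compound 2 (within the scatter) shows nothing beyond the scatter, and the step of no change at the digits printed from compound 2 to compound 3 (within the scatter) likewise shows nothing.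

Compound 4 `Fc1ccc(Cn2cnc3c(Sc4ccc(F)cc4)ncnc32)cc1` is not yet measured. It differs from compound 2 by 4-fluorophenyl in place of hydrogen on a saturated chain carbon bound to an aromatic nitrogen, which cut one bond further out reads methyl to 4-fluorobenzyl.

Neither measured step bears directly on this change: both alter an aromatic carbon, whereas the change to compound 4 sits on the saturated chain carbon bound to an aromatic nitrogen. What the measured steps do show is that adding fluoro or 4-(methylsulfanyl)phenyl left the read-out flat. Among the measured compounds shown here, with no step in hand that moved the read-out, no step beyond the scatter is expected for a number 2 percentage points higher from compound 2 to compound 4 (within the scatter). Compound 4 is expected to give 2%, with a range from -8% to 14%.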

Compound 4, a percentage reported as inhibition, at one concentration (the size of the read-out at that concentration, not a potency): 0%
Beside the measured number, compound 4's estimate is 2 percentage points above it; the range from low to high includes it.
By their numbers in this assay, from the lowest: compounds 1, 2, 3 and 4 (each within the scatter of the next).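

In this assay, among the compounds shown here, the change from methyl to 4-fluorobenzyl gives no change at the digits printed from compound 2 to compound 4 (within the scatter) and is the first step read at the saturated chain carbon bound to an aromatic nitrogen. The flat read-out, seen until now only for changes on an aromatic carbon, therefore also holds for this second kind of position and for a group that brings in a further six-membered aromatic ring. No measurement at hand accounts for the absence of a step at this position.

With all four compounds level, the series does not yet show whether any change to the shared core or its groups can lift the read-out at the concentration tested. As far as these compounds go, whether an amine, a carboxylic acid or a longer chain on the saturated chain carbon bound to an aromatic nitrogen would move the number remains open.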